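The source may hold more compounds than are shown below. What is called first, only, known or untested is meant among the compounds shown, and "the series" means these compounds.

Compound 1 `CC(C)(C(=O)O)c1nn(Cc2cn3cc(OCC4CC4)c(Cl)cc3n2)c2ccccc2c1=O` gives 317 mL/min/kg in an ADME assay on cells (Hepatocyte, Mus musculus) for metabolic stability, read by LC-MS, with a stated time of 180 min, tested at 1 uM (on this read-out lower numbers stand for slow clearance and higher numbers for fast clearance), the highest number among the values shown. Compound 2 `C[C@H](C(=O)O)n1nc(Cn2cc3cc(OCC4CC4)c(Cl)cc3n2)c2ccccc2c1=O` gives 63.3 mL/min/kg in this assay. Compound 3 `O=C(O)Cn1nc(Cn2cc3cc(OCC4CC4)c(Cl)cc3n2)c2ccccc2c1=O` reaches only the floor of this assay, < 40 mL/min/kg, which is a limit and not a number (the limit of < 40 mL/min/kg in this assay, at which 1 of the 3 values shown sits). Compound 4 `CC(C(=O)O)c1nn(Cc2cn3cc(OCC4CC4)c(Cl)cc3n2)c2ccccc2c1=O` has not yet been measured in this assay; it differs from compound 1 by hydrogen in place of methyl on a saturated chain carbon bound to an aromatic carbon, a carbonyl carbon and a saturated chain carbon. Within the data shown here, one measured step bears on this change: an at least 1.5-fold lower number from compound 2 to compound 3 (0.19 log units; that floor lies within the scatter). That step is itself only a floor lying within the scatter, so no more than a modest fall is indicated. Compound 4 is therefore expected to show a lower number, a 2.1-fold lower number from compound 1 to compound 4 (0.32 log units; beyond the scatter). The estimate for compound 4 is 150 mL/min/kg, ranging from 60 mL/min/kg to 320 mL/min/kg.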

Compound 4, clearance: 76.7 mL/min/kg
Beside the measured number, compound 4's estimate is 2.0-fold (0.29 log units) above it; measured number inside the range.
By their numbers in this assay, from the lowest: compounds 2 and 4 (each within the scatter of the next); then compound 1. At a limit, below all of these: compound 3.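

In this assay, hydrogen in place of methyl on this saturated chain carbon gives a 4.1-fold lower number from compound 1 to compound 4 (0.62 log units; beyond the scatter), so the change now has a full number on both sides and a size beyond the scatter, which the earlier step, ending at a limit, could not give. Whether the size of the change depends on the core stays unsettled: the same change on two cores in this assay, an at least 1.5-fold lower number (0.19 log units; that floor lies within the scatter) from compound 2 to compound 3 and a 4.1-fold lower number (0.62 log units; beyond the scatter) from compound 1 to compound 4; the limit leaves it open whether they differ

The compounds shown leave open whether a carboxymethyl group, with hydrogen in place of the remaining methyl, would lower the number further on the core of compound 1. They also leave open how an ethyl on that carbon would read.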